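Swapping sulfur for selenium in a cinnamoyl amide

The compounds below may be only part of what the source reports. "The series", "measured", "known", "first", "only" and "open" are said of these compounds alone.

This short series measures how strongly each compound partitions into oil rather than water, in a physicochemical assay for lipophilicity, read by HPLC, measured as octanol-water partition; on this read-out lower numbers stand for lower lipophilicity and higher numbers for higher lipophilicity. Compound 1, `COc1ccc(N(CC(=O)NCCC[Se]c2ccccc2)C(=O)c2ccccc2)cc1`, carries a benzoyl group and a selenium-bearing ring on its side chain; in this assay compound 1 gives 3.1. Compound 2, `COc1ccc(N(CC(=O)NCCCSc2ccccc2)C(=O)/C=C/c2ccccc2)cc1`, carries a cinnamoyl group instead and a phenylsulfanyl group on its side chain; in this assay compound 2 gives 4. Compound 2 thus stands highest of the two numbers recorded, and its gap to compound 1 lies beyond the usual scatter. Compound 1 and compound 2 differ in two places at once, so the two values show only their sum, not a single step.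

Compound 3, `COc1ccc(N(CC(=O)NCCC[Se]c2ccccc2)C(=O)/C=C/c2ccccc2)cc1`, keeps the cinnamoyl group of compound 2 and makes one change: a group of 7 heavy atoms (6 carbon, 1 selenium; one six-membered aromatic ring of carbon only) in place of a group of 7 heavy atoms (6 carbon, 1 sulfur; one six-membered aromatic ring of carbon only), on a saturated chain carbon, three bonds along the chain from an amide-type nitrogen. Within the data shown here, no measured pair isolates this exchange. Since compound 2 gives 4, the expectation is that this assay reports for compound 3 a value of 4.2, within 3.8 to 4.6. The expected step of a number 0.20 log units higher from compound 2 to compound 3 (within the scatter) is small and likely within the scatter, leaning slightly upward.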

Compound 3, partition coefficient: 3.7
For compound 3 the middle estimate is 0.50 log units above the measured one; measured number outside the range, below it.
By their numbers in this assay, from the lowest: compound 1; then compounds 3 and 2 (each within the scatter of the next).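

Among these compounds, with compound 3 in hand, each of the two differences between the earlier compounds can be read on its own. Phenylsulfanyl and its selenium counterpart, on a saturated chain carbon, three bonds along the chain from an amide-type nitrogen, give a step in this assay of (a number 0.30 log units lower from compound 2 to compound 3 (within the scatter)), so at this position and with a cinnamoyl group in place, the read-out does not separate sulfur from selenium. The other exchange, 2-phenylethenyl in place of phenyl on a carbonyl carbon, gives a step of (a number 0.60 log units higher from compound 1 to compound 3 (beyond the scatter)), and of the two exchanges it is the only one that the read-out clearly separates, although nothing measured here explains either step.

The compounds shown leave open whether sulfur and selenium would also read alike when the carbonyl carbon carries phenyl rather than 2-phenylethenyl. They also leave open how the number would respond if an amine or a carboxylic acid took the place of the phenylsulfanyl group, or if a longer chain carried it.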